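A few compounds are considered here, and "the series" means these few. Any claim that something is new, unique, unknown or untested is made for them only; others in the source may bear on it.

Measured compounds:
- compound 1, `Cc1ccnc(/C(N)=N/NC(=S)N2CCOCC2)c1`: 6800 nM
- compound 2, `Cc1ccnc(/C(N)=N/NC(=S)N2CCSCC2)c1`: 7200 nM
- compound 3, `N/C(=N\NC(=S)N1CCSCC1)c1ccc(F)cn1`: 1200 nM

Of the compounds shown here, three have been measured in a functional assay on A-431 cells (Homo sapiens) for cytotoxicity, read by MTT assay, with a stated time of 72 h; a higher number here means a weaker inhibitor, a lower number a stronger inhibitor. In this assay compound 1 gives 6800 nM, and compound 2 gives 7200 nM. These two share one core and differ by a single change, (morpholin-4-yl in place of thiomorpholin-4-yl on a thiocarbonyl carbon); the step between them is a 1.1-fold lower number from compound 2 to compound 1 (0.02 log units; within the scatter). Compound 3 gives 1200 nM, the lowest number of the three, and its distance to both compound 1 and compound 2 lies beyond the scatter, so compound 3 is the strongest inhibitor among the measured compounds. Compound 3 carries a different core from compound 2; the difference between the two cores is not broken down here.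

Compound 4, `N/C(=N\NC(=S)N1CCOCC1)c1ccc(F)cn1`, has not yet been measured. It is related to compound 3 by morpholin-4-yl in place of thiomorpholin-4-yl on a thiocarbonyl carbon, the same change that leads from compound 2 to compound 1, made at the same place. Because the earlier step of a 1.1-fold lower number from compound 2 to compound 1 (0.02 log units; within the scatter) stayed within the scatter, the step from compound 3 to compound 4 is expected to be about as small, roughly a 1.1-fold lower number from compound 3 to compound 4 (0.04 log units; within the scatter). As far as these compounds go, this expectation rests only on that one earlier pair and on the value of compound 3, 1200 nM, and the new core around the change is untested for this swap. Compound 4 is therefore estimated at 1100 nM, with a range from 500 nM to 2600 nM.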

Compound 4, half-maximal inhibitory concentration: 4000 nM
The estimate for compound 4 lay 3.6-fold (0.56 log units) below the measured number; measured number above the stated range.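

In this assay, putting morpholin-4-yl in place of thiomorpholin-4-yl on a thiocarbonyl carbon was not a silent change on the second core, where it gave a 3.3-fold higher number from compound 3 to compound 4 (0.52 log units; beyond the scatter). For the compounds shown here, the size of this change therefore did not carry over from one core to the other, as the two steps set side by side show: the same change on two cores in this assay, a 1.1-fold lower number (0.02 log units; within the scatter) from compound 2 to compound 1 and a 3.3-fold higher number (0.52 log units; beyond the scatter) from compound 3 to compound 4, 3.5-fold (0.55 log units) apart, beyond the scatter of two such steps Within these four compounds, the effect of the swap depends on the core around it, but this rests on only two pairs and does not show which feature of the two cores sets the steps apart, nor how the swap would behave on a third core.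

The compounds shown leave open how a piperidin-1-yl or 4-methylpiperazin-1-yl group on the same thiocarbonyl carbon would read on either core, and so whether the gap between the steps is peculiar to morpholin-4-yl and thiomorpholin-4-yl. They also leave open whether that gap follows the fluorine of one core or the methyl group of the other, a question that a core carrying a chlorine or a methoxy group could help to separate.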